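Chloro in place of ethyl: compound 2 to compound 4

This account rests on a few compounds, and the source may have more. Where it says the series, first, only, none or still open, it means among the compounds named here.

In a functional assay on A-375 cells (Homo sapiens) for inhibition, read by CCK-8 assay, with a stated time of 72 h, tested at 2 uM (a lower number here means less inhibition of growth, a higher number more inhibition of growth at the concentration tested), compound 2 `CCc1ccc(SCc2ccc(C(=O)Nc3ccccc3N)cc2)cc1` gives 19.6%. Compound 1 `Nc1ccccc1NC(=O)/C=C/c1ccc(CSc2ccc(Cl)cc2)cc1` gives 13.4%. These two compounds lie within the scatter of each other. Compound 3 `Nc1ccccc1NC(=O)/C=C/c1ccc(CSCCc2ccccc2)cc1` gives 41.9%. Compound 3 stands higher than compound 2, and that gap lies beyond the scatter. Compound 4 `Nc1ccccc1NC(=O)c1ccc(CSc2ccc(Cl)cc2)cc1` is not yet measured. Its change from compound 2 is chloro in place of ethyl on an aromatic carbon. Going by the values given here, the one measured step shows a number 28.5 percentage points higher from compound 1 to compound 3 (beyond the scatter) for phenethyl in place of 4-chlorophenyl on a sulfur, a different change that says little here. Compound 1 also carries 4-chlorophenyl and gives 13.4% in this read-out. No step beyond the scatter is expected in this assay here. The estimated step reads a number 1.6 percentage points lower from compound 2 to compound 4 (within the scatter) and stays small. For compound 4 the estimate is 18% with an expected range of 6% to 34% in this read-out.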

Compound 4, percent growth inhibition at one concentration: 25.3%
The estimate for compound 4 lay 7.3 percentage points below the measured number, within the range that was stated.
By their numbers in this assay, from the lowest: compounds 1, 2 and 4 (each within the scatter of the next, the first and the last beyond it); then compound 3.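

In this assay, chloro in place of ethyl on an aromatic carbon, para to a large group, gives a number 5.7 percentage points higher from compound 2 to compound 4 (within the scatter). At the single concentration tested, this position therefore accepts 4-chlorophenyl for 4-ethylphenyl with no separation between the two compounds. No measured evidence bears on the reason for this result.

From the compounds shown here alone, whether an amine, a carboxylic acid or a longer chain at this position would stand apart from chloro and ethyl remains open. Also open, going by these compounds, is whether phenethyl on the sulfur would give a step beyond the scatter on the core of compound 4.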